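A few compounds are considered here, and "the series" means these few. Any claim that something is new, unique, unknown or untested is made for them only; others in the source may bear on it.

Of the compounds shown here, three have been measured in a functional assay on cells (Cancer cell lines, Homo sapiens) for cytotoxicity, read by sulforhodamine B assay, with a stated time of 48 h; a higher number here means a weaker inhibitor of growth, a lower number a stronger inhibitor of growth. Compound 1 `COc1ccc(C2=NN(C3=NC(=O)/C(=C4\C(=O)Nc5ccc(Br)cc54)S3)C(c3ccc(OC)cc3)C2)cc1` gives 200 nM in that assay. Compound 2 `COc1ccc(C2=NN(C3=NC(=O)/C(=C4\C(=O)Nc5ccc(Cl)cc54)S3)C(c3ccc(OC)cc3)C2)cc1` differs from compound 1 by a single change, (chloro in place of bromo on an aromatic carbon), and in this assay compound 2 gives 190 nM. The resulting step is a 1.1-fold lower number from compound 1 to compound 2 (0.02 log units; within the scatter), so the two halogens give numbers that cannot be told apart here. Compound 3 `CN(C)c1ccc(C2CC(c3ccccc3)=NN2C2=NC(=O)/C(=C3\C(=O)Nc4ccc(Br)cc43)S2)cc1` is built on a different core; the difference between the two cores is not broken down here. In this assay compound 3 gives 200 nM, level with compound 1 at the digits shown.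

Compound 4 `CN(C)c1ccc(C2CC(c3ccccc3)=NN2C2=NC(=O)/C(=C3\C(=O)Nc4ccc(Cl)cc43)S2)cc1` has not yet been measured. It differs from compound 3 by chloro in place of bromo on an aromatic carbon, the same change at the same place as that from compound 1 to compound 2. The expected step is a 1.1-fold lower number from compound 3 to compound 4 (0.02 log units; within the scatter), resting on the earlier step of a 1.1-fold lower number from compound 1 to compound 2 (0.02 log units; within the scatter) that stayed within the scatter. In this assay compound 4 is therefore estimated at 190 nM, expected to lie between 100 nM and 380 nM.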

Compound 4, concentration for 50% growth inhibition: 190 nM
Beside the measured number, compound 4's estimate shows no gap at the digits printed; the measured number falls inside the stated range.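

In this assay, chloro in place of bromo on the aromatic carbon gives a 1.1-fold lower number from compound 3 to compound 4 (0.02 log units; within the scatter) and so leaves the two halogens indistinguishable on this second core as well. The change therefore behaves alike on both cores, with no difference that can be read between the two steps: the same change on two cores in this assay, a 1.1-fold lower number (0.02 log units; within the scatter) from compound 1 to compound 2 and a 1.1-fold lower number (0.02 log units; within the scatter) from compound 3 to compound 4, 1.0-fold (0.00 log units) apart, within the scatter of two such steps. This shows only that a swap between these two halogens left the number within the scatter on the two cores shown; it does not show that the same would hold on a third core, or that a change with a clear effect would carry over just as faithfully.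

Both steps are too small to test that harder question, so the series shown cannot say whether a substituent with a readable effect would transfer between these cores. As far as these compounds go, it remains open how the number would respond if fluoro, an amine or a carboxylic acid stood at that same place on either core.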